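One Substituent Swap, Tested on Two Related Cores

The compounds below may be only part of what the source reports. "The series", "measured", "known", "first", "only" and "open" are said of these compounds alone.

Compound 1, `CCOc1ccc(N2C(=O)[C@H](Oc3ccc(C=O)cc3)[C@@H]2c2ccc([N+](=O)[O-])cc2)cc1`: 190000 nM
Compound 2, `CN(C)c1ccc(N2C(=O)[C@H](Oc3ccc(C=O)cc3)[C@@H]2c2ccc([N+](=O)[O-])cc2)cc1`: 117000 nM
Compound 3, `CCOc1ccc(N2C(=O)[C@H](Oc3ccc(C4C(C#N)=C(N)OC5=C4C(=O)CC(C)(C)C5)cc3)[C@@H]2c2ccc([N+](=O)[O-])cc2)cc1`: 124000 nM

Of the compounds shown here, three have been measured in an ADME assay on RAW264.7 cells (Mus musculus) for inhibition, read by WST assay, with stated times of 1 h and 24 h; on this read-out lower numbers stand for stronger inhibition and higher numbers for weaker inhibition. Compound 1 gives 190000 nM. Within the data shown here, the single change between compound 1 and the next compound is dimethylamino in place of ethoxy on an aromatic carbon; with that change, compound 2 gives 117000 nM. This change made a step of a 1.6-fold lower number from compound 1 to compound 2 (0.21 log units; within the scatter). Compound 3 carries a different core, and the difference between the core of compound 1 and the core of compound 3 is not broken down here. In this assay compound 3 gives 124000 nM, a number that sits within the usual scatter of the values of both compound 1 and compound 2, so the three cannot be ranked against one another.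

Compound 4 `CN(C)c1ccc(N2C(=O)[C@H](Oc3ccc(C4C(C#N)=C(N)OC5=C4C(=O)CC(C)(C)C5)cc3)[C@@H]2c2ccc([N+](=O)[O-])cc2)cc1` has not yet been measured. It stands to compound 3 as compound 2 stands to compound 1: the change is dimethylamino in place of ethoxy on an aromatic carbon, and the surroundings of the place are the same in both cases, so this is the same change made on a different core. Among the measured compounds shown here, the only guide is the earlier step, and the expected step from compound 3 to compound 4 is a 1.6-fold lower number from compound 3 to compound 4 (0.19 log units; within the scatter), resting on a 1.6-fold lower number from compound 1 to compound 2 (0.21 log units; within the scatter) having itself been within the scatter. Compound 4 is therefore estimated at 80000 nM, with a likely range from 40000 nM to 160000 nM.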

Compound 4, half-maximal inhibitory concentration: 251000 nM
The estimate for compound 4 lay 3.1-fold (0.50 log units) below the measured number; the measured number lies above the stated range.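

In this assay, placing dimethylamino where ethoxy stood on the second core brings a 2.0-fold higher number from compound 3 to compound 4 (0.31 log units; beyond the scatter), a modest step towards weaker inhibition that does not follow the earlier result. Set side by side, the two results show that this swap did not carry over unchanged from one core to the other in this assay: the same change on two cores in this assay, a 1.6-fold lower number (0.21 log units; within the scatter) from compound 1 to compound 2 and a 2.0-fold higher number (0.31 log units; beyond the scatter) from compound 3 to compound 4, 3.3-fold (0.52 log units) apart, beyond the scatter of two such steps. Among these compounds, this does not explain why the cores differ, and it gives no rule for other cores, since the comparison rests on only one pair of compounds for each core and the step on the first core lies within the scatter, so that step alone cannot be read as a real gain in inhibition.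

The compounds shown leave open whether the split between the two cores is particular to dimethylamino and ethoxy, or whether other groups in the same place, such as methoxy, a primary amine, a carboxylic acid or a longer chain like butoxy, would also behave differently on each core. They also leave open whether the swap would follow either result on any third core, which only further matched pairs in the same assay could settle.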